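The compounds below may be only part of what the source reports. "The series", "measured", "known", "first", "only" and "open" are said of these compounds alone.

Compound 1 `COc1ccccc1-c1cc(=O)c2cc(NC(C)=O)ccc2o1` and compound 2 `CC(=O)Nc1ccc2oc(-c3ccccc3F)cc(=O)c2c1` share one core. In an ADME assay on MT4 cells (Homo sapiens) for cytotoxicity, read by MTT assay, with a stated time of 4 days (a lower number here means that less compound is tolerated, a higher number that more compound is tolerated), compound 1 gives 226000 nM, and compound 2 gives 205000 nM. Among the compounds with values here, the single measured step, a 1.1-fold lower number from compound 1 to compound 2 (0.04 log units; within the scatter), shows the two numbers lying within the scatter of each other. Compound 3 `COc1ccccc1-c1cc(=O)c2cc(N)ccc2o1` departs from compound 1 at another place: hydrogen in place of acetyl on a nitrogen on an aromatic ring. Within the data shown here, no measured step covers this change, and the one known step altered a different part of the molecule, so nothing suggests a shift beyond the scatter. Compound 3 is therefore expected to give about 200000 nM, between 100000 nM and 400000 nM, an estimated step of a 1.1-fold lower number from compound 1 to compound 3 (0.05 log units; within the scatter).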

Compound 3, half-maximal cytotoxic concentration: 198000 nM
The estimate for compound 3 lay 1.0-fold (0.00 log units) above the measured number; the measured number falls inside the stated range.
By their numbers in this assay, from the lowest: compounds 3, 2 and 1 (each within the scatter of the next).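

Swapping acetamido for amino on the shared core gives a 1.1-fold lower number from compound 1 to compound 3 (0.06 log units; within the scatter) in this assay, so removing the acetyl from this nitrogen leaves the number within the scatter. The earlier step showed this only for a change at a different place, and the molecule has now been altered at two places with no step beyond the scatter. No measured evidence here accounts for this result. Going by these compounds, whether a longer acyl chain on this nitrogen, or a carboxylic acid in place of the amino group, would also stay within the scatter remains open.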